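The source may report more compounds than this note shows. Statements on the series, on what has been measured and on what is new or still open speak of the compounds shown alone.

Within the data shown here, the study measures an assay on membranes from HEK293 cells for displacement of a labelled ligand from Translocator protein (Homo sapiens), read by scintillation counting, with a stated time of 90 min (a higher number here means a weaker inhibitor, a lower number a stronger inhibitor), and three compounds have numbers so far. Compound 2 `CC(=O)N(Cc1ccccc1)c1cc(C)cc(C)c1` gives 276 nM in this assay. Compound 3 `CCN(CC)C(=O)CN(Cc1ccccc1)c1cc(C)cc(C)c1` gives 1010 nM in this assay. Compound 1 `CCN(CC)C(=O)c1nc2ccccc2n1Cc1ccc(OC)nc1` reaches only a limit of this assay, > 10000 nM, which is a boundary of the measurement and not a number (the limit of > 10000 nM in this assay, at which 1 of the 3 values shown sits). Among the two numbers, compound 3 stands highest, and its nearest neighbour is compound 2; the step of a 3.7-fold higher number from compound 2 to compound 3 (0.56 log units; beyond the scatter) is the only measured step, and it changes the group on the ring nitrogen rather than the benzyl ring.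

Compound 4 `CCN(CC)C(=O)CN(Cc1ccc(OCCF)cc1)c1cc(C)cc(C)c1` differs from compound 3 in one place: 2-fluoroethoxy in place of hydrogen on an aromatic carbon, on a six-membered aromatic ring of carbon only, para to a large group. Among the measured compounds shown here, no measured step touches this position, so the step of a 3.7-fold higher number from compound 2 to compound 3 (0.56 log units; beyond the scatter) bears on it only indirectly, as a sign that this series can move by a modest amount with a single change. With no direct comparison in hand, the expected step is within the scatter, with a wide range in either direction. The step from compound 3 to compound 4 is expected to be a 1.3-fold lower number from compound 3 to compound 4 (0.10 log units; within the scatter). Compound 4 is therefore expected to give about 800 nM in this assay, with a range from 200 nM to 3000 nM.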

Compound 4, inhibition constant: 1290 nM
Estimate against measurement, compound 4: 1.6-fold (0.21 log units) below; the range from low to high includes it.
By their numbers in this assay, from the lowest: compound 2; then compounds 3 and 4 (each within the scatter of the next). At a limit, above all of these: compound 1.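

The step at this position now has a reading: in this assay, 2-fluoroethoxy in place of hydrogen on an aromatic carbon, para to a large group, comes with a 1.3-fold higher number from compound 3 to compound 4 (0.11 log units; within the scatter), so the two compounds cannot be told apart. Among these compounds, the position thus accepts 4 heavy atoms, with no ring and no net charge, and the number stays within the scatter, whereas the only earlier step, made at the group on the nitrogen, was a 3.7-fold higher number from compound 2 to compound 3 (0.56 log units; beyond the scatter) and lay beyond it. Nothing in the evidence at hand bears on why this result comes out as it does.

The compounds shown leave open whether a methoxy group, a longer chain, an amine or a carboxylic acid at this same place would also stay within the scatter of compound 3, or whether any group here can move the number at all. They also leave open whether 2-fluoroethoxy would behave the same way on compound 2, which carries acetyl on the nitrogen and gives 276 nM in this assay.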